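Removing the chlorinated aromatic arm from compound 2

The source may report more compounds than this note shows. Statements on the series, on what has been measured and on what is new or still open speak of the compounds shown alone.

In a functional assay on cells (T-cell line, Homo sapiens) for inhibition (a higher number here means a weaker inhibitor, a lower number a stronger inhibitor), compound 1 (`COc1ccccc1CCCN1CCC(COC(c2ccccc2)c2ccccc2)CC1`) gives 2400 nM and compound 2 (`Clc1ccccc1CCCN1CCC(COC(c2ccccc2)c2ccccc2)CC1`) gives 800 nM. Compound 2 therefore holds the lower of the two numbers and is the stronger inhibitor of this pair.

The next compound, compound 3 (`CCN1CCC(COC(c2ccccc2)c2ccccc2)CC1`), keeps the shared core but loses most of the chain on the amine nitrogen: hydrogen in place of 2-chlorobenzyl on a saturated chain carbon, two bonds along the chain from an amine nitrogen in a ring. The same difference can be read as 3-(2-chlorophenyl)propyl to ethyl.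

Among the compounds with values here, only one measured step bears on this change, and it bears indirectly. The step of a 3.0-fold lower number from compound 1 to compound 2 (0.48 log units; beyond the scatter) is modest, and it comes from chloro in place of methoxy on the aromatic ring that compound 3 no longer carries. Within the data shown here, it shows that this assay responds to a single substituent on that ring, but no measured compound lacks the ring altogether. A larger move towards a higher number, meaning weaker inhibition, is therefore expected, though with wide uncertainty.

The expected step is a 10-fold higher number from compound 2 to compound 3 (1.00 log units; beyond the scatter). For compound 3 the estimated value is 8000 nM, with an expected range from 2000 nM to 35000 nM.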

Compound 3, half-maximal inhibitory concentration: > 20000 nM
Compound 3 ended at the assay's limit; the forecaster's own chance of this, stated with the estimate: 25%; middle value at least 2.5-fold (0.39 log units) away from the limit.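

Compound 3 gives > 20000 nM in this assay, and this value is a limit of the assay, not a number: the limit of > 20000 nM in this assay, at which 1 of the 3 values shown sits.

Even so, replacing the 3-(2-chlorophenyl)propyl group with ethyl gives an at least 25-fold higher number from compound 2 to compound 3 (1.39 log units; beyond the scatter), and the comparison with the methoxy-bearing arm gives an at least 8.3-fold higher number from compound 1 to compound 3 (0.92 log units; beyond the scatter). Within the data shown here, both steps are beyond the scatter, so the earlier picture, in which the only change was a substituent swap giving a 3.0-fold lower number from compound 1 to compound 2 (0.48 log units; beyond the scatter), is now joined by a much larger dependence on the arm as a whole: with only ethyl on the amine nitrogen of the shared core, inhibition falls to the limit of this assay.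

The compounds shown leave open how far compound 3 really lies from compound 2, and whether the loss follows from removing the aromatic ring, the chain length or the chloro group. A plain 3-phenylpropyl group, or a 2-(2-chlorophenyl)ethyl group or longer chain carrying the same ring, would begin to separate these contributions.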